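A few compounds are considered here, and "the series" means these few. Any claim that something is new, unique, unknown or untested is made for them only; others in the source may bear on it.

Measured compounds:
compound 1, `COc1ccc(-c2cc(C(=O)/C=C/c3ccccc3)nc3cc(-c4ccccc4)nn23)cc1OC`, in a functional assay on DU-145 cells (Homo sapiens) for antiproliferative activity, read by MTT assay, with a stated time of 24 h (a higher number here means a weaker inhibitor, a lower number a stronger inhibitor), compound 1 gives 15600 nM;
compound 2, `COc1ccc(C(=O)/C=C/c2cc(-c3cc(OC)c(OC)c(OC)c3)n3nc(-c4ccccc4)cc3n2)cc1`, where compound 2 gives 25200 nM;
compound 3, `COc1cc(-c2cc(C(=O)/C=C/c3ccc(Cl)cc3)nc3cc(-c4ccccc4)nn23)cc(OC)c1OC`, where compound 3 gives 19500 nM.

On these three numbers compound 3 stands second highest; its nearest neighbour is compound 1 and its furthest is compound 2, and both gaps lie within the scatter, so no order among the three can be claimed. Among the compounds with values here, the one step between neighbours that differ in one place, a 1.3-fold lower number from compound 2 to compound 3 (0.11 log units; within the scatter), is also within the scatter.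

Compound 4, `COc1cc(-c2cc(C(=O)/C=C/c3ccccc3)nc3cc(-c4ccccc4)nn23)cc(OC)c1OC`, differs from compound 3 only at the far end of the chain: hydrogen in place of chloro on an aromatic carbon. Within the data shown here, no measured step touches this exact change. Compound 1 carries the same plain phenyl group but differs from compound 3 in more than one place, and its value sits within the scatter of compound 3. Among the measured compounds shown here, with no step reaching beyond the scatter, no shift beyond the scatter is expected; the step of a 1.1-fold lower number from compound 3 to compound 4 (0.03 log units; within the scatter) is estimated as flat. Compound 4 is therefore expected to give about 18000 nM, within 9000 nM to 40000 nM.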

Compound 4, half-maximal inhibitory concentration: 16300 nM
Compound 4: the middle estimate sits 1.1-fold (0.04 log units) above what was measured; low and high end bracket the measured number.
By their numbers in this assay, from the lowest: compounds 1, 4, 3 and 2 (each within the scatter of the next).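

Hydrogen in place of chloro on the aromatic carbon para to a large group gives a 1.2-fold lower number from compound 3 to compound 4 (0.08 log units; within the scatter) in this assay and is the first direct reading at this position, showing that the chloro can go without a shift beyond the scatter. With the plain phenyl group kept, methoxy in place of hydrogen on an aromatic carbon gives a 1.0-fold higher number from compound 1 to compound 4 (0.02 log units; within the scatter) and is likewise flat. The change of (2-phenylethenyl)carbonyl in place of 2-((4-methoxyphenyl)carbonyl)ethenyl gives a 1.5-fold lower number from compound 2 to compound 4 (0.19 log units; within the scatter) and also stays within the scatter, and no independent evidence bears on these results.

The compounds shown carry only chloro or hydrogen at this carbon, so whether an amine or a carboxylic acid there would move the number beyond the scatter stays open. The same holds for a longer chain in place of the ethenyl unit.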